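The source may hold more compounds than are shown below. What is called first, only, known or untested is meant among the compounds shown, and "the series" means these compounds.

Compound 1 `COc1ccc2c(c1)C(n1ccccc1=O)=CC(C)(C)O2`: 6.55
Compound 2 `CC(=O)Oc1ccc2c(c1)C(n1ccccc1=O)=CC(C)(C)O2`: 5.6

Two compounds share a core and differ only at an oxygen on an aromatic ring. In a functional assay (aorta) with Rattus norvegicus as the target (a higher number here means a more potent compound, by a factor of ten per unit of this negative logarithm, a lower number a less potent compound), compound 1 gives 6.55, and compound 2 gives 5.6. For the measured compounds named here, compound 2 thus stands lowest of the two, the one step measured, a number 0.95 log units lower from compound 1 to compound 2 (beyond the scatter), lying beyond the scatter.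

Compound 3 `CC1(C)C=C(n2ccccc2=O)c2cc(OCC(=O)c3ccccc3)ccc2O1` has not yet been measured in this assay. Its structure departs from compound 2 as follows: benzoylmethyl in place of acetyl on an oxygen on an aromatic ring. Going by the values given here, no measured step covers this exact change; the only step available, a number 0.95 log units lower from compound 1 to compound 2 (beyond the scatter), shows that replacing methyl with acetyl at the same oxygen cost potency. Compound 3 carries an ether at that oxygen again, as compound 1 does, though with a much larger group, so a modest rise relative to compound 2 is expected, a number 0.60 log units higher from compound 2 to compound 3 (beyond the scatter), without a full return to the value of compound 1. Compound 3 is therefore estimated at 6.2, with a likely range from 5.5 to 6.9.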

Compound 3, logarithm of the reciprocal of the active concentration, log(1/C): 5.05
Compound 3: middle estimate off by 1.15 log units, on the high side; the whole stated range lies above it.
By their numbers in this assay, from the lowest: compound 3; then compound 2; then compound 1.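

The result shows that an ether at this oxygen does not by itself keep potency in this assay: with benzoylmethyl in place of acetyl, the change is a number 0.55 log units lower from compound 2 to compound 3 (beyond the scatter), and with benzoyl in place of hydrogen on the saturated chain carbon bound to the oxygen, it is a number 1.50 log units lower from compound 1 to compound 3 (beyond the scatter). The earlier pair could be read as a contrast between an ether and an ester, but compound 3, an ether, falls below the ester compound 2, so that reading does not hold across the three compounds, and the order instead follows the size of the group, with methyl highest, acetyl next and benzoylmethyl lowest, with none of the three going against it. The data shown offer no explanation for this fall.

The compounds shown leave open whether the loss follows the aromatic ring or the carbonyl of benzoylmethyl, which a benzyl group or a plain ethyl chain on the same oxygen would help to separate. They also leave open how a free hydroxyl, an amine or a carboxylic acid carried on a short chain at this oxygen would compare.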